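Swapping a Chlorophenyl for an Imidazole in a Cytotoxicity Series

The source may hold more compounds than are shown below. What is called first, only, known or untested is meant among the compounds shown, and "the series" means these compounds.

Compound 3 `COc1ccc(-c2cnc(NC(=O)c3ccccc3Cl)n2C)cc1` belongs to a small set of three close relatives examined in a toxicity assay on THP-1 cells (Homo sapiens) for inhibition; a higher number here means that more compound is tolerated, a lower number that less compound is tolerated. The reading for compound 3 is > 50000 nM, which is a limit of the assay rather than a number. Compound 1 `COc1ccc(-c2cnc(NC(=O)c3cccnc3)n2C)cc1` gives > 100000 nM in this assay, also only a limit. Compound 2 `COc1ccc(-c2cnc(NC(=O)C3CCCC3)n2C)cc1` gives > 100000 nM in this assay, again a limit. With all three values sitting at limits, the three steps between them cannot be sized: a step that the two limits leave unreadable from compound 1 to compound 2, a step that the two limits leave unreadable from compound 1 to compound 3 and a step that the two limits leave unreadable from compound 2 to compound 3. So compound 3 stands where its two companions stand, at a limit, and nothing in the measured set shows one compound tolerated better than another.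

Compound 4 `COc1ccc(-c2cnc(NC(=O)c3ncc[nH]3)n2C)cc1` differs from compound 3 in a single place: 1H-imidazol-2-yl in place of 2-chlorophenyl on a carbonyl carbon. For the measured compounds named here, the three measured steps all concern the group on this same carbonyl carbon, which makes them the only relevant comparisons, yet each is unreadable, so they give no size and no direction for the present change. The step from compound 3 to compound 4 is therefore expected to be a step that the limit leaves unreadable from compound 3 to compound 4, nothing beyond the scatter. Compound 4 is estimated to give 100000 nM in this assay, within a range of 30000 nM to 300000 nM, most probably reported again only as a limit.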

Compound 4, half-maximal cytotoxic concentration: > 100000 nM
Compound 4: no number, only a limit; the forecaster's own chance of this, stated with the estimate: 85%; the middle value sits exactly at the limit.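

In this assay compound 4 gives > 100000 nM, which is a limit and not a number, so its steps from compound 1, compound 2 and compound 3 cannot be read. The compounds shown leave open whether the group on the carbonyl carbon changes how much compound is tolerated at all.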